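Removing a Methyl at the Cytotoxicity Limit

The source may hold more compounds than are shown below. What is called first, only, known or untested is meant among the compounds shown, and "the series" means these compounds.

Of the compounds shown here, three sharing one core have been tested in an ADME assay on HEp-2 cells (Homo sapiens) for cytotoxicity, read by CCK-8 assay, with a stated time of 6 days; on this read-out higher numbers stand for lower toxicity in this test and lower numbers for higher toxicity in this test. Compound 1 `O=c1n(Cc2nc3ccc(Cl)cn3c2CCCCO)c2cnccc2n1C1CC1` carries a chloro group on an aromatic carbon; in this assay compound 1 gives > 100000 nM, which is a limit of the assay rather than a number. Compound 2 `O=c1n(Cc2nc3ccc(C(F)(F)F)cn3c2CCCCO)c2cnccc2n1C1CC1` carries trifluoromethyl instead; in this assay compound 2 gives > 100000 nM, again a limit. Among the measured compounds shown here, the single change between them, trifluoromethyl in place of chloro on an aromatic carbon, is a step that the two limits leave unreadable from compound 1 to compound 2. Compound 3 `Cc1ccn2c(CCCCO)c(Cn3c(=O)n(C4CC4)c4ccncc43)nc2c1` carries a methyl group; in this assay compound 3 gives > 100000 nM, also a limit. Compound 3 thus stands where the other two stand, since (the limit of > 100000 nM in this assay, at which 3 of the 3 values shown sit).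

Compound 4 `O=c1n(Cc2nc3ccccn3c2CCCCO)c2cnccc2n1C1CC1` differs from compound 3 by hydrogen in place of methyl on an aromatic carbon. For the measured compounds named here, the only measured step, the one from compound 1 to compound 2, also swaps a group on an aromatic carbon, yet the two limits leave its size unreadable, so it offers no measured size to lean on. With every measured value resting at the limit, no readable movement in this assay is expected. The expected step is a step that the limit leaves unreadable from compound 3 to compound 4. Compound 4 is therefore estimated at 150000 nM, within a range from 60000 nM to 400000 nM.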

Compound 4, half-maximal cytotoxic concentration: > 100000 nM
Compound 4: only a limit was reported (the forecaster's own chance of this, stated with the estimate: 85%); the middle value is on the limit's open side.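

Compound 4 also ends at a limit of the assay, so no size can be read for its steps from compound 1, compound 2 or compound 3: the limit of > 100000 nM in this assay, at which 4 of the 4 values shown sit.

The compounds shown leave open whether any of these swaps on an aromatic carbon changes the result in this assay, and at what concentration any of the four compounds would show toxicity.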